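The source may report more compounds than this note shows. Statements on the series, on what has been measured and on what is new or still open speak of the compounds shown alone.

Compound 1 `CC(C)n1nc2c(c1-c1ccccc1)CCNCC2` gives 28 nM in an assay on HEK293 cells for displacement of a labelled ligand from 5-hydroxytryptamine receptor 7 (Rattus norvegicus), read by radioligand binding (on this read-out lower numbers stand for stronger inhibition and higher numbers for weaker inhibition), the lowest of the three numbers shown, although its separation from compound 2 is within the scatter. Compound 2 `CC(C)(C)n1nc2c(c1-c1ccccc1)CCNCC2`, with tert-butyl in place of isopropyl on the aromatic nitrogen, gives 30 nM in this assay, and the step of a 1.1-fold higher number from compound 1 to compound 2 (0.03 log units; within the scatter) is within the scatter. Compound 3 `c1ccc(-c2c3c(nn2C2CCC2)CCNCC3)cc1`, which carries cyclobutyl on that nitrogen, gives 90 nM in this assay; the steps of a 3.2-fold higher number from compound 1 to compound 3 (0.51 log units; beyond the scatter) and a 3.0-fold higher number from compound 2 to compound 3 (0.48 log units; beyond the scatter) are modest but beyond the scatter. Every measured step alters only the group on the aromatic nitrogen.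

Compound 4 `Cc1ccc(-c2c3c(nn2C(C)C)CCNCC3)cc1` differs from compound 1 at a different site: methyl in place of hydrogen on an aromatic carbon. None of the three measured steps touches the six-membered aromatic ring of carbon only, so none of them bears directly on this change, and the available numbers give no direction for it. In the absence of a comparable step, the expected outcome in this assay is no step beyond the scatter, a 1.1-fold higher number from compound 1 to compound 4 (0.03 log units; within the scatter), with a correspondingly wide range. Compound 4 is therefore estimated to give 30 nM in this assay, expected to fall between 10 nM and 90 nM.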

Compound 4, inhibition constant: 6 nM
Estimate against measurement, compound 4: 5.0-fold (0.70 log units) above; measured number below the stated range.
By their numbers in this assay, from the lowest: compound 4; then compounds 1 and 2 (each within the scatter of the next); then compound 3.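

In this assay the step of a 4.7-fold lower number from compound 1 to compound 4 (0.67 log units; beyond the scatter) shows that the six-membered aromatic ring of carbon only is a place where the number can move beyond the scatter, and that a single added carbon, para to a large group, is enough to do it. Among the steps from compound 1, this is the only one that lowers the number beyond the scatter: the step of a 1.1-fold higher number from compound 1 to compound 2 (0.03 log units; within the scatter) stays within the scatter, and the step of a 3.2-fold higher number from compound 1 to compound 3 (0.51 log units; beyond the scatter) goes the other way. Nothing shown here accounts for the size or direction of this step.

As far as these compounds go, whether methyl is special at this place, or whether chlorine, methoxy or trifluoromethyl in the same place would give a similar number, remains open, as does the outcome of methyl elsewhere on that ring. The compounds shown pair this methyl only with isopropyl on the aromatic nitrogen, so whether the step carries over to the tert-butyl of compound 2 or the cyclobutyl of compound 3 also remains open.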